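The source may hold more compounds than are shown below. What is called first, only, known or untested is meant among the compounds shown, and "the series" means these compounds.

In an ADME assay on MT4 cells (Homo sapiens) for cytotoxicity, read by MTT assay, with a stated time of 4 days (a lower number here means that less compound is tolerated, a higher number that more compound is tolerated), compound 1 `COc1cccc(-c2cc(=O)c3cc(NC(C)=O)ccc3o2)c1` gives > 404000 nM, which is a limit of the assay. Compound 3 `COc1cccc(-c2oc3ccc(NC(C)=O)cc3c(=O)c2O)c1` stands lowest of the actual numbers at 33300 nM, and compound 2 `CC(=O)Nc1ccc2oc(-c3ccc(F)cc3)cc(=O)c2c1` gives 203000 nM. Compound 4 `CC(=O)Nc1ccc2oc(-c3ccc(F)cc3)c(O)c(=O)c2c1` keeps the hydroxy group of compound 3 but has 4-fluorophenyl in place of 3-methoxyphenyl on an aromatic carbon. Going by the values given here, the one measured step bearing on this is the hydroxy in place of hydrogen, a large change with an at least 12-fold lower number from compound 1 to compound 3 (1.08 log units; beyond the scatter). Compound 2 carries 4-fluorophenyl without that hydroxy at 203000 nM, so a similar drop would bring compound 4 close to compound 3. The expected change is small and within the scatter, namely a 1.7-fold lower number from compound 3 to compound 4 (0.22 log units; within the scatter). Compound 4 is estimated at 20000 nM, within an expected range of 7000 nM to 60000 nM.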

Compound 4, half-maximal cytotoxic concentration: 34100 nM
Compound 4: middle estimate off by 1.7-fold (0.23 log units), on the low side; low and high end bracket the measured number.
By their numbers in this assay, from the lowest: compounds 3 and 4 (each within the scatter of the next); then compound 2. At a limit, above all of these: compound 1.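

In this assay, 4-fluorophenyl in place of 3-methoxyphenyl on the hydroxy-bearing core stays within the scatter, with a 1.0-fold higher number from compound 3 to compound 4 (0.01 log units; within the scatter). Hydroxy in place of hydrogen now also appears on a second core, with a 6.0-fold lower number from compound 2 to compound 4 (0.77 log units; beyond the scatter). The lower number thus comes with the hydroxy group on both aryl cores, though the sizes of the two steps cannot be compared: the same change on two cores in this assay, an at least 12-fold lower number (1.08 log units; beyond the scatter) from compound 1 to compound 3 and a 6.0-fold lower number (0.77 log units; beyond the scatter) from compound 2 to compound 4; the limit leaves it open whether they differ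

The compounds shown leave open how an amine or a carboxylic acid on the phenyl ring would read. Going by these compounds, whether a methoxy group in place of the hydroxy group would give the same drop also remains open.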